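The source may hold more compounds than are shown below. What is called first, only, known or untested is meant among the compounds shown, and "the series" means these compounds.

The study measured two compounds in a functional assay on SUP-B15 cells (Homo sapiens) for antiproliferative activity, with a stated time of 72 h; a higher number here means that more compound is needed for the effect, a lower number that less compound is needed. Compound 1 `COc1ccc(-c2c(Br)c(=O)c3c(OC)cc(OC)cc3n2S(=O)(=O)c2ccc(OC)cc2)cc1` gives 2920 nM. Compound 2 `COc1cc(OC)c2c(=O)cc(C(=O)Nc3cc(C(F)(F)F)ccc3Oc3ccccc3OC)[nH]c2c1` reaches only the limit of the assay, > 53400 nM, so no number is known for it; its value stands at the limit of > 53400 nM in this assay, at which 1 of the 2 values shown sits. Compound 3 `COc1ccc(Oc2ccc(C(F)(F)F)cc2NC(=O)c2cc(=O)c3c(OC)cc(OC)cc3[nH]2)cc1` has not yet been measured. It differs from compound 2 by 4-methoxyphenyl in place of 2-methoxyphenyl on an oxygen on an aromatic ring. Within the data shown here, no measured pair in this set shows the effect of such a move, so the expectation rests on compound 2 alone, which gives only a limit. The step that the limit leaves unreadable from compound 2 to compound 3 is therefore expected to be small, with a real chance that the assay again reports only a limit. Compound 3 is expected to give about 60000 nM, within a range from 15000 nM to 250000 nM.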

Compound 3, half-maximal effective concentration: > 67200 nM
Compound 3: no number, only a limit; the forecaster's own chance of this, stated with the estimate: 70%; at least 1.1-fold (0.04 log units) between middle value and limit.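

In this assay, compound 2 and compound 3 each give only a limit, so no step can be read between them. The compounds shown leave open whether 4-methoxyphenyl in place of 2-methoxyphenyl changes the effect at all, since neither compound has a number.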